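Fluoro to Trifluoromethoxy: Will Cells Still Tolerate It?

The compounds below may be only part of what the source reports. "The series", "measured", "known", "first", "only" and "open" are said of these compounds alone.

How much of a compound can living cells bear? In a toxicity assay on HEK293 cells (Homo sapiens) for inhibition, read by resazurin assay, with a stated time of 24 h (a lower number here means that less compound is tolerated, a higher number that more compound is tolerated), compound 1 (`NC(=O)c1ncc([N+](=O)[O-])[nH]1`) gives > 100000 nM as its result, which is a limit of the assay and not a number. Compound 2 (`NC(=O)c1nc([N+](=O)[O-])cn1Cc1ccc(F)cc1`) gives > 100000 nM as its result, again a limit. Compound 2 therefore has no exact figure, and its place is known only as the limit of > 100000 nM in this assay, at which 2 of the 2 values shown sit, and nothing finer.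

Compound 3 (`NC(=O)c1nc([N+](=O)[O-])cn1Cc1ccc(OC(F)(F)F)cc1`) differs from compound 2 in one place, with trifluoromethoxy in place of fluoro on an aromatic carbon, para to a large group (trifluoromethoxy in place of fluoro on an aromatic carbon). Going by the values given here, no measured step is available to gauge such a swap, so the expectation is cautious: in this assay no change beyond the usual scatter is expected, in either direction. That expectation leans on compound 2, whose > 100000 nM stands as a limit of the assay. The estimated step of a number no higher from compound 2 to compound 3 (the limit leaves the size open) is accordingly expected to be small. For compound 3 the estimated half-maximal cytotoxic concentration is 100000 nM (expected range 40000 nM to 200000 nM) and the assay may well report only a limit again.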

Compound 3, half-maximal cytotoxic concentration: > 100000 nM
Compound 3: only a limit was reported (the forecaster's own chance of this, stated with the estimate: 75%); the middle value sits exactly at the limit.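

In this assay compound 3 gives > 100000 nM as its result, which is a limit of the assay and not a number. Going by these compounds alone, compound 2 also has only a limit, so no step between compound 2 and compound 3 can be read. How much of any of these compounds cells would tolerate stays open, since all the results share one ceiling: the limit of > 100000 nM in this assay, at which 3 of the 3 values shown sit.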